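The source may hold more compounds than are shown below. What is called first, only, known or untested is meant among the compounds shown, and "the series" means these compounds.

In a functional assay for inhibition, with Rattus norvegicus as the target (on this read-out higher numbers stand for weaker inhibition and lower numbers for stronger inhibition), compound 1 `CC(/N=c1\c(O)c(O)\c1=N/c1ccccc1)C(C)(C)C` gives 5400 nM, the higher of the two exact numbers in this small set. Compound 3 `CC(/N=c1\c(O)c(O)\c1=N/c1ccc(C#N)cc1)C(C)(C)C` reads 520 nM. Compound 2 `CC(/N=c1\c(O)c(O)\c1=N/c1ccc(S(N)(=O)=O)cc1)C(C)(C)C` gives only a limit, > 30000 nM. Compound 4 `CC(/N=c1\c(O)c(O)\c1=N/c1cccc(C#N)c1)C(C)(C)C` differs from compound 1 by cyano in place of hydrogen on an aromatic carbon. The closest measured step is a 10-fold lower number from compound 1 to compound 3 (1.02 log units; beyond the scatter), a large one for the same replacement of hydrogen by cyano. That cyano, however, sits on a different aromatic carbon. The step of an at least 5.5-fold higher number from compound 1 to compound 2 (0.74 log units; beyond the scatter) runs the other way but brings in a different group. For the measured compounds named here, a lower number is therefore expected, though by a smaller margin, as no measured compound carries cyano at this place. The estimated step is a 5.4-fold lower number from compound 1 to compound 4 (0.73 log units; beyond the scatter). For compound 4 the expected value is 1000 nM, with an estimated range of 250 nM to 4000 nM.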

Compound 4, half-maximal inhibitory concentration: 3050 nM
Estimate against measurement, compound 4: 3.1-fold (0.48 log units) below, and the stated range covers the measured number.
By their numbers in this assay, from the lowest: compound 3; then compounds 4 and 1 (each within the scatter of the next). At a limit, above all of these: compound 2.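

Placed meta to a large group, cyano gives a 1.8-fold lower number from compound 1 to compound 4 (0.25 log units; within the scatter) in this assay, so at this carbon the replacement of hydrogen does not separate the two compounds. The large step seen with cyano in compound 3 therefore does not hold for every aromatic carbon: compound 3 reads 520 nM with cyano on a different aromatic carbon, while compound 4 reads 3050 nM with it meta to a large group. The compounds shown offer no explanation for this difference between the two carbons. Going by these compounds, whether an amine or a carboxylic acid on the carbon that carries cyano in compound 4 would move the number stays open.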